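The source may report more compounds than this note shows. Statements on the series, on what has been measured and on what is new or still open speak of the compounds shown alone.

Measured so far in an assay on isolated protein for binding affinity to 5-hydroxytryptamine receptor 7 (Rattus norvegicus); on this read-out higher numbers stand for weaker inhibition and lower numbers for stronger inhibition:
Compound 1 `COc1ccccc1N1CCN(CCCCCC(=O)c2ccccc2O)CC1` gives 5.8 nM.
Compound 2 `CN1CCN(CCCCCC(=O)c2ccccc2O)CC1` gives only a limit of the assay, > 1000 nM, sitting at the limit of > 1000 nM in this assay, at which 1 of the 3 values shown sits.
Compound 3 `O=C(CCCCCN1CCN(c2ccccc2)CC1)c1ccccc1O` gives 43 nM.

Compound 3 thus holds the highest of the two numbers; its nearest neighbour is compound 1, with a 7.4-fold higher number from compound 1 to compound 3 (0.87 log units; beyond the scatter). Compound 4 `O=C(CCCCCN1CCN(c2cccc(C(F)(F)F)c2)CC1)c1ccccc1O` differs from compound 3 by trifluoromethyl in place of hydrogen on an aromatic carbon. Of the measured steps, the aryl group itself matters greatly, as an at least 170-fold higher number from compound 1 to compound 2 (2.23 log units; beyond the scatter) and an at least 23-fold lower number from compound 2 to compound 3 (1.36 log units; beyond the scatter) show, while a substituent on that ring gave the modest 7.4-fold higher number from compound 1 to compound 3 (0.87 log units; beyond the scatter). For a trifluoromethyl no direct comparison exists. In this assay compound 4 is therefore expected to move at most modestly, most likely to a lower number, a 1.4-fold lower number from compound 3 to compound 4 (0.16 log units; within the scatter). The estimate for compound 4 is 30 nM, between 9 nM and 120 nM.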

Compound 4, inhibition constant: 384 nM
For compound 4 the middle estimate is 13-fold (1.11 log units) below the measured one; measured number outside the range, above it.
By their numbers in this assay, from the lowest: compound 1; then compound 3; then compound 4. At a limit, above all of these: compound 2.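

In this assay, adding a substituent to the phenyl ring does not necessarily help: trifluoromethyl gives the weaker binding seen in the step (an 8.9-fold higher number from compound 3 to compound 4 (0.95 log units; beyond the scatter)). The choice and place of the substituent matter, as the exchange of 2-methoxyphenyl for 3-(trifluoromethyl)phenyl shows (a 66-fold higher number from compound 1 to compound 4 (1.82 log units; beyond the scatter)). The 3-(trifluoromethyl)phenyl group still binds more strongly than methyl (an at least 2.6-fold lower number from compound 2 to compound 4 (0.41 log units; beyond the scatter)), a step read against a limit: the limit of > 1000 nM in this assay, at which 1 of the 4 values shown sits. The compounds shown leave open whether the higher number follows from trifluoromethyl itself or from its place on the ring. A methoxy or a chlorine at this same place could separate the two.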